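A few compounds are considered here, and "the series" means these few. Any claim that something is new, unique, unknown or untested is made for them only; others in the source may bear on it.

Measured in a functional assay on NCI-H522 cells (Homo sapiens) for cytotoxicity, read by sulforhodamine B assay, with a stated time of 48 h, tested at 10 uM; a higher number here means a weaker effect of the compound at the concentration tested, a lower number a stronger effect:
compound 1 `COc1ccc(-c2cc(/C=C/C(=O)c3ccc(N)cc3)[nH]n2)cc1` gives -70%
compound 2 `COc1cc(-c2cc(/C=C/C(=O)c3ccc(N)cc3)[nH]n2)cc(OC)c1OC` gives -51%
compound 3 `COc1cc(-c2cc(/C=C/C(=O)c3ccc(Cl)c(Cl)c3)[nH]n2)cc(OC)c1OC` gives -72%

Compound 2 stands highest of the three numbers in this assay: compound 1 lies beyond the scatter below it, and compound 3 lies further below still. The step to compound 4 `COc1cc(-c2cc(/C=C/C(=O)c3ccc(F)c(F)c3)[nH]n2)cc(OC)c1OC` changes compound 2 in one place: 3,4-difluorophenyl in place of 4-aminophenyl on a carbonyl carbon. Going by the values given here, one measured step bears on this: a number 21 percentage points lower from compound 2 to compound 3 (beyond the scatter), where a 3,4-dichlorophenyl replaced the same 4-aminophenyl on the same carbonyl carbon. The fluorine analogue is expected to move in the same direction, by a step of roughly similar or somewhat smaller size, so a number 14 percentage points lower from compound 2 to compound 4 (beyond the scatter) is expected. Compound 4 is therefore estimated at -65%, with a range from -82% to -48%.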

Compound 4, a percentage reported as activity, at one concentration (the size of the read-out at that concentration, not a potency): -38%
Estimate against measurement, compound 4: 27 percentage points below, outside the stated range (above it).
By their numbers in this assay, from the lowest: compounds 3 and 1 (each within the scatter of the next); then compound 2; then compound 4.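

On this carbonyl carbon, the two dihalophenyl groups do not behave alike in this assay: 3,4-difluorophenyl in place of 4-aminophenyl raises the number (a number 13 percentage points higher from compound 2 to compound 4 (beyond the scatter)), whereas 3,4-dichlorophenyl had lowered it. Exchanging only the halogens gives the largest step among these compounds (a number 34 percentage points higher from compound 3 to compound 4 (beyond the scatter)), so carrying two halogens does not by itself set the outcome here. Nothing available explains this difference. The compounds shown leave open where a 3,4-dibromophenyl or a 4-chlorophenyl group would fall on this carbonyl carbon. They also leave open whether 3,4-difluorophenyl would act the same way on the core of compound 1.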